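Adding a chloro group to the core of compound 1

This account rests on a few compounds, and the source may have more. Where it says the series, first, only, none or still open, it means among the compounds named here.

Compound 1 `O=C(N/N=C/c1ccc(CO)c2ccccc12)c1ccc(O)c(Cl)c1` gives 41.1 nM in an assay on BHK cells for binding affinity to Glucagon receptor (Homo sapiens); a lower number here means a stronger inhibitor, a higher number a weaker inhibitor. Of the two compounds measured in this assay, compound 1 has the highest number; the nearest is compound 2 `O=C(N/N=C/c1ccc(CO)c2ccccc12)c1ccc(O)c(F)c1`, which gives 29.4 nM. Going by the values given here, the one measured step, a 1.4-fold lower number from compound 1 to compound 2 (0.15 log units; within the scatter), comes from fluoro in place of chloro on an aromatic carbon and stays within the scatter. Compound 3 `O=C(N/N=C/c1ccc(CO)c2ccccc12)c1ccc(O)c(Cl)c1Cl` differs from compound 1 by chloro in place of hydrogen on an aromatic carbon. Among the compounds with values here, no measured step adds a group to this ring; the only step available swaps one halogen for another, and it was within the scatter. The added chloro is therefore expected to give a step within the scatter, with no clear direction. In this assay the expected step is a 1.2-fold lower number from compound 1 to compound 3 (0.07 log units; within the scatter). Compound 3 is estimated at 35 nM, with a range from 12 nM to 110 nM.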

Compound 3, half-maximal inhibitory concentration: 53.8 nM
The estimate for compound 3 lay 1.5-fold (0.19 log units) below the measured number; the range from low to high includes it.
By their numbers in this assay, from the lowest: compounds 2, 1 and 3 (each within the scatter of the next).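

In this assay, chloro in place of hydrogen on this aromatic carbon, ortho to a chloro group and ortho to a large group, gives a 1.3-fold higher number from compound 1 to compound 3 (0.12 log units; within the scatter) and so stays within the scatter. The earlier step only exchanged one halogen for another on a different carbon, whereas this one shows that the carbon carrying hydrogen in compound 1 accepts a chloro with no clear change in the number. Nothing available bears on why the step is this size.

Open, on these data alone, is whether a methoxy group, an amine or a carboxylic acid on this same carbon would give a step beyond the scatter. Also open, as far as these compounds go, is whether the added chloro would give a similar step with fluoro in place of the existing chloro.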